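From 2,4-dichlorophenyl to 2,4-dimethoxyphenyl on a shared core

The source may hold more compounds than are shown below. What is called first, only, known or untested is meant among the compounds shown, and "the series" means these compounds.

Compound 1 `OC[C@H]1O[C@@H](n2cnc3c(NCc4ccccc4Cl)ncnc32)[C@H](O)[C@@H]1O`: > 166000 nM (a limit)
Compound 2 `OC[C@H]1O[C@@H](n2cnc3c(NCc4ccc(Cl)cc4Cl)ncnc32)[C@H](O)[C@@H]1O`: 127000 nM

Going by the values given here, in a functional assay on MCF cells (Homo sapiens) for antiproliferative activity, with a stated time of 72 h (a lower number here means a stronger inhibitor, a higher number a weaker inhibitor), compound 2 gives 127000 nM, the only true number so far. Compound 1 has only a limit, (the limit of > 166000 nM in this assay, at which 1 of the 2 values shown sits). Compound 3 `COc1ccc(CNc2ncnc3c2ncn3[C@@H]2O[C@H](CO)[C@@H](O)[C@H]2O)c(OC)c1` has 2,4-dimethoxyphenyl in place of 2,4-dichlorophenyl on a saturated chain carbon bound to a nitrogen on an aromatic ring. Among the compounds with values here, the single measured step, an at least 1.3-fold lower number from compound 1 to compound 2 (0.11 log units; that floor lies within the scatter), is a different change and stays within the scatter, so it supports no expected shift in this assay beyond the scatter. The expected size is a 1.1-fold lower number from compound 2 to compound 3 (0.02 log units; within the scatter). For compound 3 the estimate is 120000 nM, with an expected range of 50000 nM to 260000 nM.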

Compound 3, half-maximal inhibitory concentration: > 166000 nM
Compound 3 was reported as a limit (the forecaster's own chance of this, stated with the estimate: 40%); middle value at least 1.3-fold (0.14 log units) away from the limit.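

In this assay, the move to 2,4-dimethoxyphenyl on a saturated chain carbon bound to a nitrogen on an aromatic ring gives an at least 1.3-fold higher number from compound 2 to compound 3 (0.11 log units; that floor lies within the scatter), so this change brings no lower number than 2,4-dichlorophenyl. The value for compound 3 is a limit, and it is the same limit as for compound 1: the limit of > 166000 nM in this assay, at which 2 of the 3 values shown sit. The step from compound 1 to compound 3 cannot be read, as both values are limits.

Going by these compounds, the true size of the step from compound 2 remains open. So does whether an amine or a carboxylic acid on the phenyl ring, or a longer chain in place of the saturated chain carbon, would lower the number.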